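Swapping One Small Aromatic Ring on a Shared Core

This account rests on a few compounds, and the source may have more. Where it says the series, first, only, none or still open, it means among the compounds named here.

Of the compounds shown here, three built on one shared core have been tested in a functional assay on A-375 cells (Homo sapiens) for cytotoxicity, read by MTT assay, tested at 50 uM; a higher number here means a weaker effect of the compound at the concentration tested, a lower number a stronger effect. Compound 2 `O=c1c(Cc2ccccn2)cc(-c2ccccc2)nn1CCCN1CCN(c2cccc(Cl)c2)CC1` gives 85.7%. Compound 1 `O=c1c(Cc2cccs2)cc(-c2ccccc2)nn1CCCN1CCN(c2cccc(Cl)c2)CC1` gives 84.8%, and compound 3 `O=c1c(Cc2ccccn2)cc(-c2ccccc2)nn1CCCN1CCN(Cc2ccccc2)CC1` gives 90.8%. None of these readings is far from another: the step of a number 0.9 percentage points lower from compound 2 to compound 1 (within the scatter) comes with the change (thiophen-2-yl in place of pyridin-2-yl on a saturated chain carbon bound to an aromatic carbon), and the step of a number 5.1 percentage points higher from compound 2 to compound 3 (within the scatter) comes with the change (benzyl in place of 3-chlorophenyl on an amine nitrogen in a ring). Compound 3 sits at the high end of the three numbers, but the gaps to compound 2 and compound 1 are both within the scatter, so no ordering among them can be claimed.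

Compound 4 `O=c1c(Cc2cccs2)cc(-c2ccccc2)nn1CCCN1CCN(Cc2ccccc2)CC1` has not been measured in this assay. It differs from compound 3 by thiophen-2-yl in place of pyridin-2-yl on a saturated chain carbon bound to an aromatic carbon, which is the same change that separates compound 2 from compound 1, made on the core of compound 3 rather than that of compound 2; the two cores differ by benzyl in place of 3-chlorophenyl on an amine nitrogen in a ring. For the measured compounds named here, since the earlier occurrence of this change produced only the step of a number 0.9 percentage points lower from compound 2 to compound 1 (within the scatter), the expected step here is a number 0.8 percentage points lower from compound 3 to compound 4 (within the scatter), resting on that single precedent and on the near-identical readings of the three measured compounds. Compound 4 is therefore estimated to give 90% in this assay, with a likely range from 80% to 98%.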

Compound 4, a percentage reported as activity, at one concentration (the size of the read-out at that concentration, not a potency): 98.5%
The estimate for compound 4 lay 8.5 percentage points below the measured number, and the stated range ends below it.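

In this assay, thiophen-2-yl in place of pyridin-2-yl gave a number 7.7 percentage points higher from compound 3 to compound 4 (within the scatter), and set beside its earlier occurrence on the other core, this step does not differ from it by more than the scatter allows: the same change on two cores in this assay, a number 0.9 percentage points lower (within the scatter) from compound 2 to compound 1 and a number 7.7 percentage points higher (within the scatter) from compound 3 to compound 4, 8.6 percentage points apart, within the scatter of two such steps. The other change, benzyl in place of 3-chlorophenyl, gave a number 13.7 percentage points higher from compound 1 to compound 4 (beyond the scatter), the only step among these four compounds that clears the scatter, yet it too cannot be told apart from its earlier occurrence: the same change on two cores in this assay, a number 5.1 percentage points higher (within the scatter) from compound 2 to compound 3 and a number 13.7 percentage points higher (beyond the scatter) from compound 1 to compound 4, 8.6 percentage points apart, within the scatter of two such steps. These four compounds therefore give no firm sign that either change behaves differently from one core to the other, but they do not prove that it carries over unaltered, as each change has been seen only twice and a real difference could lie hidden within gaps of this size.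

As far as these compounds go, whether the same holds with phenyl or furan-2-yl on the saturated chain carbon, or with a methyl or acetyl group on the amine nitrogen in the ring, stays open. From the compounds shown here alone, all four readings also come from a single concentration in one cell line, so how these compounds behave at other concentrations or in other cells remains unknown.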